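This account rests on a few compounds, and the source may have more. Where it says the series, first, only, none or still open, it means among the compounds named here.

Two compounds of the series carry numbers in a functional assay on MKN-45 cells (Homo sapiens) for cytotoxicity, read by MTT assay, with a stated time of 72 h; a higher number here means a weaker inhibitor, a lower number a stronger inhibitor. Compound 1, `CN(C)CCCNc1nc(-c2ccc(NC(=O)Nc3ccc(F)cc3)cc2)nc2c(Cl)c(Cl)sc12`, gives 1120 nM. Compound 2, `CN(C)CCCNc1nc(-c2ccc(NC(=O)Nc3ccc(Cl)cc3Cl)cc2)nc2ccsc12`, gives 2270 nM, the highest of the two numbers; compound 1 sits at a lower number, a gap beyond the usual scatter, and the two structures differ in more than one place, so nothing further is read from that pair.

Compound 3 is `CN(C)CCNc1nc(-c2ccc(NC(=O)Nc3ccc(Cl)cc3Cl)cc2)nc2ccsc12`. It differs from compound 2 in one place: dimethylamino in place of (dimethylamino)methyl on a saturated chain carbon, two bonds along the chain from a nitrogen on an aromatic ring. Among the compounds with values here, no measured pair shows this change, so the size of its effect in this assay is open; a step no larger than the scatter is expected, in either direction. Compound 3 is estimated at 2500 nM, with a range from 1000 nM to 6500 nM, meaning an expected step of a 1.1-fold higher number from compound 2 to compound 3 (0.04 log units; within the scatter).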

Compound 3, half-maximal inhibitory concentration: 2360 nM
The estimate for compound 3 lay 1.1-fold (0.03 log units) above the measured number, and the stated range covers the measured number.
By their numbers in this assay, from the lowest: compound 1; then compounds 2 and 3 (each within the scatter of the next).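

In this assay, within the data shown here, the change from (dimethylamino)methyl to dimethylamino on this saturated chain carbon gives the first single-place pair of the series (a 1.0-fold higher number from compound 2 to compound 3 (0.02 log units; within the scatter)). At this position, 3-(dimethylamino)propyl and 2-(dimethylamino)ethyl therefore read alike on this one background. No measured evidence bears on why the two chains read alike.

Going by these compounds, a longer chain, or a morpholine or primary amine in place of the dimethylamino end, remains open at this position. Also open, on these data alone, is whether the same step holds on the core of compound 1.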